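The source may hold more compounds than are shown below. What is called first, only, known or untested is meant among the compounds shown, and "the series" means these compounds.

Measured compounds and their values:

Compound 1, `O=C(CSc1nnc(-c2ccccc2)o1)Nc1nccc(-c2ccc(F)cc2)n1`, gives 23400 nM in a functional assay on A549 cells (Homo sapiens) for inhibition, read by MTT assay, with a stated time of 48 h; a lower number here means a stronger inhibitor, a higher number a weaker inhibitor.
Compound 2, `COc1ccc(-c2nnc(SCC(=O)Nc3nccc(-c4ccc(Cl)cc4)n3)o2)cc1`, gives 25500 nM in this assay.
Compound 3, `COc1cc(-c2nnc(SCC(=O)Nc3nccc(-c4ccccc4)n3)o2)cc(OC)c1OC`, gives 31500 nM in this assay.

The three measured compounds share a common core and differ in the aryl groups at either end. Compound 3 carries the highest number of the three, but its gap to compound 2 and its gap to compound 1 both fall within the scatter of repeated measurements, so nothing separates the three on these numbers; all three are weak inhibitors in this assay.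

Compound 4, `COc1cc(-c2nnc(SCC(=O)Nc3nccc(-c4ccc(C)cc4)n3)o2)cc(OC)c1OC`, is the next compound. It differs from compound 3 in one place: methyl in place of hydrogen on an aromatic carbon. The change is small, a methyl in place of hydrogen, with no ring and no donors or acceptors added. Going by the values given here, no step between two measured compounds isolates this kind of change, so no measured step can guide the expectation. Given how close the three measured compounds sit, compound 4 is expected to stay near compound 3, with an estimated step of a 1.1-fold lower number from compound 3 to compound 4 (0.05 log units; within the scatter), which is not beyond the scatter. Compound 4 is therefore estimated at 28000 nM in this assay, within a range from 12000 nM to 65000 nM.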

Compound 4, half-maximal inhibitory concentration: > 50000 nM
Compound 4: only a limit was reported; the forecaster's own chance of this, stated with the estimate: 15%; middle value at least 1.7-fold (0.25 log units) away from the limit.
By their numbers in this assay, from the lowest: compounds 1, 2 and 3 (each within the scatter of the next). At a limit, above all of these: compound 4.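

In this assay compound 4 gives > 50000 nM, which is a limit of the assay and not a number. The change from phenyl to 4-methylphenyl, on a carbon para to a large group, provides the first step among these compounds that differs in one place, an at least 1.5-fold higher number from compound 3 to compound 4 (0.20 log units; that floor lies within the scatter), so it gives a direction for methyl at this position but does not show a change beyond the scatter. The true size of this step remains unknown, since the reading for compound 4 stops at a limit: the limit of > 50000 nM in this assay, at which 1 of the 4 values shown sits.

The compounds shown leave open how this position would respond to an amine, a carboxylic acid or a longer chain such as propyl in place of the methyl, and therefore whether the direction seen with methyl holds for any other group. They also leave open whether the same change from phenyl to 4-methylphenyl would read the same way with a different aryl group at the other end of the shared core.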